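Nitro for Chloro on Two Cores

The compounds below may be only part of what the source reports. "The series", "measured", "known", "first", "only" and "open" are said of these compounds alone.

Measured compounds in a functional assay on HCT-116 cells (Homo sapiens) for antiproliferative activity, read by MTT assay, with a stated time of 72 h; a lower number here means a stronger inhibitor of growth, a higher number a weaker inhibitor of growth:
compound 1, `Clc1cccc(Nc2nc3ncccc3n2Cc2ccccc2)c1`, gives 36300 nM
compound 2, `O=[N+]([O-])c1cccc(Nc2nc3ncccc3n2Cc2ccccc2)c1`, gives 41700 nM
compound 3, `Cn1nc(-c2ccnc(Nc3cccc(Cl)c3)n2)c2ccccc21`, gives 6400 nM

Compound 1 and compound 2 share a core and differ by nitro in place of chloro on an aromatic carbon; in this assay this gave a 1.1-fold higher number from compound 1 to compound 2 (0.06 log units; within the scatter). Compound 3 has a different core, and the difference between the two cores is not broken down here. Its number in this assay is beyond the scatter from both compound 1 and compound 2.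

Compound 4, `Cn1nc(-c2ccnc(Nc3cccc([N+](=O)[O-])c3)n2)c2ccccc21`, differs from compound 3 by nitro in place of chloro on an aromatic carbon, the same change as from compound 1 to compound 2. The step expected from compound 3 to compound 4 in this assay is a 1.1-fold higher number from compound 3 to compound 4 (0.04 log units; within the scatter), which rests on the step of a 1.1-fold higher number from compound 1 to compound 2 (0.06 log units; within the scatter). Compound 4 is therefore estimated at 7000 nM, between 3000 nM and 16000 nM.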

Compound 4, concentration for 50% growth inhibition: 490 nM
Compound 4: the middle estimate sits 14-fold (1.15 log units) above what was measured, outside the stated range (below it).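

In this assay, nitro in place of chloro on an aromatic carbon gave a 13-fold lower number from compound 3 to compound 4 (1.12 log units; beyond the scatter), so the change did not carry over from one core to the other at the same size: the same change on two cores in this assay, a 1.1-fold higher number (0.06 log units; within the scatter) from compound 1 to compound 2 and a 13-fold lower number (1.12 log units; beyond the scatter) from compound 3 to compound 4, 15-fold (1.18 log units) apart, beyond the scatter of two such steps. In these two pairs, then, the step read on one core could not stand in for the step on the other. This does not show which part of the cores accounts for the gap or how it arises, and two pairs make no rule for the series.

The compounds shown leave open whether an amine or a nitrile at the same place would follow nitro on the core of compound 3. They also leave open whether either group would give a step of similar size on the core of compound 1.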